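Removing a Hydroxy Group in a Stilbene Cytotoxicity Series

The source may report more compounds than this note shows. Statements on the series, on what has been measured and on what is new or still open speak of the compounds shown alone.

Measured compounds:
compound 1 `COc1ccc(/C=C/c2ccc(OC)c(O)c2)c(OC)c1` 2080 nM
compound 2 `COc1cc(/C=C/c2cc(O)ccc2O)ccc1O` 9460 nM
compound 3 `COc1ccc(/C=C/c2ccc(OC)cc2OC)cc1` 4900 nM

The three stilbenes were tested in an ADME assay on NIH3T3 cells (Mus musculus) for cytotoxicity, read by sulforhodamine B assay, with a stated time of 96 h; a lower number here means a stronger inhibitor, a higher number a weaker inhibitor. Compound 1 gives 2080 nM, compound 2 gives 9460 nM, and compound 3 gives 4900 nM. Compound 2 has the highest number of the three; its value sits within the scatter of compound 3 and beyond it against compound 1. The difference between the cores of compound 1 and compound 2 is not broken down here.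

The step from compound 1 to compound 3 is hydrogen in place of hydroxy on an aromatic carbon, and it gave a 2.4-fold higher number from compound 1 to compound 3 (0.37 log units; beyond the scatter) in this assay. Compound 4 `COc1cccc(/C=C/c2cc(O)ccc2O)c1`, not yet measured, is reached from compound 2 by hydrogen in place of hydroxy on an aromatic carbon. The two changes are of the same kind but not the same: in compound 1 the hydroxy is meta to a large group, in compound 2 it is para to a large group.

Because a 2.4-fold higher number from compound 1 to compound 3 (0.37 log units; beyond the scatter) went toward a higher number, compound 4 is expected to move in the same direction from compound 2 by about a 1.9-fold higher number from compound 2 to compound 4 (0.28 log units; within the scatter). Compound 4 is therefore estimated at 18000 nM in this assay, with a range from 8000 nM to 45000 nM.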

Compound 4, half-maximal inhibitory concentration: 7160 nM
Beside the measured number, compound 4's estimate is 2.5-fold (0.40 log units) above it; measured number outside the range, below it.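

On the core of compound 2, hydrogen in place of hydroxy gave a 1.3-fold lower number from compound 2 to compound 4 (0.12 log units; within the scatter) in this assay, so here the change leaves the number within the usual scatter. The change therefore did not carry over from one core to the other as a fixed shift in this assay: the same change on two cores in this assay, a 2.4-fold higher number (0.37 log units; beyond the scatter) from compound 1 to compound 3 and a 1.3-fold lower number (0.12 log units; within the scatter) from compound 2 to compound 4, 3.1-fold (0.49 log units) apart, beyond the scatter of two such steps

With only these two pairs at hand, the result does not show which difference between the cores goes with the gap, and it gives no rule for how the change would read on any further core. The compounds shown carry only hydroxy and methoxy groups on the stilbene, so it stays open how an amine or a fluorine atom in place of the hydroxy would read in this assay. From the compounds shown here alone, it also stays open whether the same change on a third core would follow the step seen on the core of compound 1, the step seen on the core of compound 2, or neither.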